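The compounds below may be only part of what the source reports. "The series", "measured", "known", "first", "only" and "open" are said of these compounds alone.

Measured compounds in a functional assay on A549 cells (Homo sapiens) for cytotoxicity, read by MTT assay, with a stated time of 48 h; a higher number here means a weaker inhibitor, a lower number a stronger inhibitor:
- compound 1 `COc1ccc(C(=O)C2Sc3nnc(-c4cc(OC)c(OC)c(OC)c4)n3NC2c2ccco2)cc1` gives a limit, > 100000 nM.
- compound 2 `COc1ccc(C(=O)C2Sc3nnc(-c4cc(OC)c(OC)c(OC)c4)n3NC2c2cccs2)cc1` gives a limit, > 100000 nM.
- compound 3 `COc1cc(-c2nnc3n2NC(c2ccco2)C(C(=O)c2ccc(C(F)(F)F)cc2)S3)cc(OC)c1OC` gives 37200 nM.

Going by the values given here, compound 3 therefore holds the only actual number among the three; the other two values are limits of this assay, as the limit of > 100000 nM in this assay, at which 2 of the 3 values shown sit, records. Because of those limits, the step that the two limits leave unreadable from compound 1 to compound 2 cannot be read in size. Among the compounds with values here, the one readable step is an at least 2.6-fold lower number from compound 1 to compound 3 (0.42 log units; beyond the scatter), which is at least modest and beyond the usual scatter of repeated measurements.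

Compound 4 `COc1cc(-c2nnc3n2NC(c2ccco2)C(C(=O)c2ccc([N+](=O)[O-])cc2)S3)cc(OC)c1OC` has not yet been measured. It differs from compound 3 by nitro in place of trifluoromethyl on an aromatic carbon. Within the data shown here, none of the measured steps swaps a nitro group in or out, so no step speaks directly to this change. Among the measured compounds shown here, the only readable step, an at least 2.6-fold lower number from compound 1 to compound 3 (0.42 log units; beyond the scatter), concerns a different exchange at the same kind of aromatic carbon and shows that a change there can shift the number at least modestly. For the measured compounds named here, with no direct precedent, compound 4 is expected to land near compound 3. In this assay compound 4 is expected to give about 35000 nM, with a range from 12000 nM to 100000 nM. The expected step of a 1.1-fold lower number from compound 3 to compound 4 (0.03 log units; within the scatter) is thus small, likely within the scatter, and a limit rather than a number remains a real possibility.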

Compound 4, half-maximal inhibitory concentration: > 100000 nM
Compound 4 was reported as a limit; the forecaster's own chance of this, stated with the estimate: 30%; middle value at least 2.8-fold (0.45 log units) away from the limit.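

In this assay, 4-nitrophenyl in place of 4-(trifluoromethyl)phenyl gives an at least 2.6-fold higher number from compound 3 to compound 4 (0.42 log units; beyond the scatter), so this aromatic carbon, para to a large group, does not treat the two groups alike even though neither adds a ring or a net charge. Going by these compounds alone, earlier, trifluoromethyl had been compared only with methoxy at this place; with nitro as a second comparison, trifluoromethyl is the only one of the three groups here that gives an actual number rather than a limit. Compound 4 gives a limit and not a number, so the step between compound 1 and compound 4 cannot be read in size, and methoxy and nitro cannot be ranked against each other, because both compounds sit at the same limit: the limit of > 100000 nM in this assay, at which 3 of the 4 values shown sit.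

The compounds shown leave open whether trifluoromethyl is a rare exception at this place or whether other groups, such as a chlorine atom, an amine or a carboxylic acid, would also give a number. Also open, on these data alone, is what thiophen-2-yl in place of furan-2-yl would do in a compound that carries trifluoromethyl.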